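The source may report more compounds than this note shows. Statements on the series, on what has been measured and on what is new or still open speak of the compounds shown alone.

In a functional assay on BT-483 cells (Homo sapiens) for cytotoxicity, read by MTT assay, with a stated time of 24 h (a higher number here means a weaker inhibitor, a lower number a stronger inhibitor), compound 1 `CCNc1cc(-c2ccc(NC(=O)Nc3ccc(C(F)(F)F)cc3)cc2C)ccn1` gives 19700 nM. Compound 3 `CCNc1cc(-c2ccc(NC(=O)Nc3ccc(C(F)(F)F)cc3)cc2OC)ccn1` gives 25600 nM in this assay. The two cores differ by methoxy in place of methyl on an aromatic carbon, and the step is a 1.3-fold higher number from compound 1 to compound 3 (0.11 log units; within the scatter), so the numbers of compound 1 and compound 3 cannot be told apart.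

Compound 2 `CCNc1cc(-c2ccc(NC(=O)Nc3c(C)cccc3C)cc2C)ccn1` differs from compound 1 by 2,6-dimethylphenyl in place of 4-(trifluoromethyl)phenyl on an amide-type nitrogen. For compound 2 this assay reports only a limit, > 30000 nM, and not a number. The step is therefore an at least 1.5-fold higher number from compound 1 to compound 2 (0.18 log units; that floor lies within the scatter), and its floor rests on (the limit of > 30000 nM in this assay, at which 1 of the 3 values shown sits).

Compound 4 `CCNc1cc(-c2ccc(NC(=O)Nc3c(C)cccc3C)cc2OC)ccn1` has not yet been measured. For the measured compounds named here, it differs from compound 3 by 2,6-dimethylphenyl in place of 4-(trifluoromethyl)phenyl on an amide-type nitrogen, which is the same change as the one that leads from compound 1 to compound 2, here made on the core that carries methoxy in place of methyl. Since the two cores give numbers within the scatter of each other, the change is expected to act on compound 3 as it did on compound 1. Going by the values given here, for compound 4 the expected step in this assay is a 1.8-fold higher number from compound 3 to compound 4 (0.24 log units; within the scatter), which follows the earlier step because an at least 1.5-fold higher number from compound 1 to compound 2 (0.18 log units; that floor lies within the scatter) is the only measured example of this change. Compound 4 is estimated at 45000 nM, with a range from 25000 nM to 90000 nM, and it is likely that only a limit, not a number, will be reported.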

Compound 4, half-maximal inhibitory concentration: > 30000 nM
Compound 4: only a limit was reported; the forecaster's own chance of this, stated with the estimate: 80%; the middle value does not contradict the limit.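

The change from 4-(trifluoromethyl)phenyl to 2,6-dimethylphenyl, carried onto the core of compound 3, gives an at least 1.1-fold higher number from compound 3 to compound 4 (0.06 log units; that floor lies within the scatter), and setting this beside the same change on the core of compound 1 gives only a loose comparison: the same change on two cores in this assay, an at least 1.5-fold higher number (0.18 log units; that floor lies within the scatter) from compound 1 to compound 2 and an at least 1.1-fold higher number (0.06 log units; that floor lies within the scatter) from compound 3 to compound 4; the limit leaves it open whether they differ
In this assay compound 4 gives > 30000 nM, which is a limit of the assay and not a number.
The result fits the change acting alike on both cores, but it does not prove that it does, and the true size of the change stays unknown on each core, because the two compounds with 2,6-dimethylphenyl stop at the same limit: the limit of > 30000 nM in this assay, at which 2 of the 4 values shown sit.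

The compounds shown leave open how methoxy in place of methyl acts when 2,6-dimethylphenyl is present, as the step from compound 2 to compound 4 cannot be read. They also leave open whether a different group on the amide-type nitrogen, such as a phenyl ring carrying an amine or a carboxylic acid, would give a measured number rather than a limit in this assay.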